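The compounds below may be only part of what the source reports. "The series", "measured", "known", "first", "only" and "open" are said of these compounds alone.

Measured so far:
Compound 1 `NC(C/C=C(\c1ccc(-c2ccccc2)cc1)c1ccc(F)cc1F)C(=O)O`. In a functional assay for inhibition of sodium- and chloride-dependent glycine transporter 1 (Rattus norvegicus), with a stated time of 30 min, in the presence of a further agent that is not named here (on this read-out higher numbers stand for weaker inhibition and lower numbers for stronger inhibition), compound 1 gives > 10000 nM, which is a limit of the assay and not a number.
Compound 2 `Cc1ccc(/C(=C\CC(N)C(=O)O)c2ccc(F)cc2F)cc1`. In this assay compound 2 gives 9560 nM.
Compound 3 `CCc1ccc(/C(=C\CC(N)C(=O)O)c2ccc(F)cc2F)cc1`. In this assay compound 3 gives > 10000 nM, again a limit and not a number.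

Compound 2 therefore stands as the only number shown in this assay; the two further values are limits. The measured steps are small: an at least 1.0-fold lower number from compound 1 to compound 2 (0.01 log units; that floor lies within the scatter), and an at least 1.0-fold higher number from compound 2 to compound 3 (0.01 log units; that floor lies within the scatter), each within the scatter, while a step that the two limits leave unreadable from compound 1 to compound 3. Against this sits (the limit of > 10000 nM in this assay, at which 2 of the 3 values shown sit), so the series as a whole is read against a ceiling rather than against separate numbers.

Compound 4 `NC(C/C=C(\c1cccnc1)c1ccc(F)cc1F)C(=O)O` is not yet measured. It differs from compound 2 as follows: pyridin-3-yl in place of 4-methylphenyl on a double-bonded chain carbon bound to an aromatic carbon and a double-bonded chain carbon. Among the compounds with values here, none of the measured steps exchanges a ring atom; all three vary only the group on the aromatic ring, and the change to compound 4 is of another kind. With nothing in the measured steps speaking for a movement beyond the scatter, the expected step is a 1.0-fold higher number from compound 2 to compound 4 (0.02 log units; within the scatter), and compound 4 is estimated at 10000 nM in this assay, within 3000 nM to 30000 nM, with a real chance that only a limit is reported.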

Compound 4, half-maximal inhibitory concentration: > 10000 nM
Compound 4: no number, only a limit; the forecaster's own chance of this, stated with the estimate: 50%; the middle value sits exactly at the limit.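

Pyridin-3-yl at this place, on a double-bonded chain carbon bound to an aromatic carbon and a double-bonded chain carbon, is the first change of the ring itself: a ring with a hetero atom and a hydrogen-bond acceptor enters where the earlier steps altered only the group on a carbon-only ring. In this assay this exchange gives an at least 1.0-fold higher number from compound 2 to compound 4 (0.01 log units; that floor lies within the scatter), so the ring nitrogen brings no readable separation from compound 2, and the steps that join two limits cannot be read. With compound 4 the series leans further on the ceiling, and compound 2 remains the only compound with a number: the limit of > 10000 nM in this assay, at which 3 of the 4 values shown sit.

Going by these compounds, the true size of the step to compound 4 stays open, and so does whether this place tolerates any change that yields a number clearly lower than that of compound 2. A saturated ring such as cyclohexyl, or an aromatic ring carrying a hydroxyl or an amide, would test this place in ways that neither pyridin-3-yl nor the alkylphenyl groups can.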